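The source may report more compounds than this note shows. Statements on the series, on what has been measured and on what is new or still open speak of the compounds shown alone.

In a functional assay on PC-3 cells (Homo sapiens) for cytotoxicity, read by cell counting, with a stated time of 48 h (a higher number here means a weaker inhibitor, a lower number a stronger inhibitor), compound 1 (`Cc1ccc(-n2cc(COc3cccc4cnc(Nc5cccc(Cl)c5)nc34)nn2)c([N+](=O)[O-])c1`) gives 7000 nM and stands level with compound 3 (`Clc1cccc(Nc2ncc3cccc(OCc4cn(Cc5c(Cl)cccc5Cl)nn4)c3n2)c1`), which gives 7000 nM in the same read-out. Compound 2 (`COc1ccccc1-n1cc(COc2cccc3cnc(Nc4cccc(Cl)c4)nc23)nn1`) gives 8000 nM and lies within the scatter of both.

Compound 4 (`Clc1cccc(Nc2ncc3cccc(OCc4cn(-c5ccc(Br)cc5)nn4)c3n2)c1`) is still unmeasured. It carries 4-bromophenyl in place of 4-methyl-2-nitrophenyl on an aromatic nitrogen.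

Three measured steps bear on this change, all at that same nitrogen:
- 2-methoxyphenyl in place of 4-methyl-2-nitrophenyl (a 1.1-fold higher number from compound 1 to compound 2 (0.06 log units; within the scatter))
- 2,6-dichlorobenzyl in place of 4-methyl-2-nitrophenyl (no change at the digits printed from compound 1 to compound 3 (within the scatter))
- 2,6-dichlorobenzyl in place of 2-methoxyphenyl (a 1.1-fold lower number from compound 2 to compound 3 (0.06 log units; within the scatter))

All three lie within the scatter, and none of the three compounds goes against this flat picture. Within the data shown here, no measured compound carries 4-bromophenyl, however, and three compounds are a thin basis, so the range is kept wider than the measured spread. No step beyond the scatter is expected in this assay for this exchange, and no direction can be argued from the data. The estimated step is small (a 1.1-fold lower number from compound 1 to compound 4 (0.03 log units; within the scatter)) and stays within the scatter. For compound 4 the expected value is 6500 nM (estimated range 3500 nM to 12000 nM).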

Compound 4, half-maximal inhibitory concentration: 18000 nM
Compound 4: the middle estimate sits 2.8-fold (0.44 log units) below what was measured; the measured number lies above the stated range.
By their numbers in this assay, from the lowest: compounds 1, 3 and 2 (each within the scatter of the next); then compound 4.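

In this assay the group on the aromatic nitrogen turns out not to be freely exchangeable: the replacement by 4-bromophenyl gives a 2.6-fold higher number from compound 1 to compound 4 (0.41 log units; beyond the scatter) and a 2.6-fold higher number from compound 3 to compound 4 (0.41 log units; beyond the scatter) and also a 2.3-fold higher number from compound 2 to compound 4 (0.35 log units; beyond the scatter) while the three earlier groups stayed within the scatter of one another. All three steps are modest, yet they show that this position can move the number, and that a six-membered aromatic ring of carbon only, sitting on this nitrogen, does not by itself set the level, as compound 1 and compound 2 carry such a ring and stay with compound 3 rather than with compound 4. No measurement at hand accounts for the step.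

In the compounds shown, 4-bromophenyl is the only group with bromine and the only aryl group with a single substituent, so one compound cannot separate these two features, and the series gives no view of plain phenyl, 4-chlorophenyl or 2-bromophenyl on the same nitrogen. Also open, going by these compounds, is how the number responds to a basic amine, a carboxylic acid or a longer alkyl chain at this position.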